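Aromatic substituent swap on a shared fused bicyclic core

The source may hold more compounds than are shown below. What is called first, only, known or untested is meant among the compounds shown, and "the series" means these compounds.

Three measured compounds share one core. Compound 1 `CCCS(=O)(=O)Nc1cccc2c1CCC2c1ncc[nH]1` gives 1340 nM in a functional assay on CHO cells for agonist activity at Alpha-1A adrenergic receptor (Homo sapiens), read by FLIPR and calcium flux; on this read-out higher numbers stand for an effect only at larger amounts of compound and lower numbers for an effect already at smaller amounts. Among the measured compounds shown here, compound 3 `CCS(=O)(=O)Nc1cccc2c1CCC2c1ncc[nH]1` gives 32 nM; the step of a 42-fold lower number from compound 1 to compound 3 (1.62 log units; beyond the scatter) is the only single-point comparison measured so far, and it concerns the saturated chain at the sulfonyl. Compound 2 `COc1c(Cl)ccc2c1CCC2c1ncc[nH]1` gives 451 nM and stands second highest of the three, with compound 1 above it and compound 3 below it. Compound 4 `Clc1ccc2c(c1-c1ccn[nH]1)CCC2c1ncc[nH]1` differs from compound 2 by 1H-pyrazol-5-yl in place of methoxy on an aromatic carbon. For the measured compounds named here, no measured step touches this aromatic position, so the chain step gives no guidance for the direction here; a step of either sign beyond the scatter is possible. Compound 4 is expected to give about 600 nM, estimated within 120 nM to 3000 nM. That estimate corresponds to an expected 1.3-fold higher number from compound 2 to compound 4 (0.12 log units; within the scatter).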

Compound 4, half-maximal effective concentration: 322 nM
Estimate against measurement, compound 4: 1.9-fold (0.27 log units) above, within the range that was stated.
By their numbers in this assay, from the lowest: compound 3; then compounds 4 and 2 (each within the scatter of the next); then compound 1.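

At this aromatic carbon, ortho to a chloro group, 1H-pyrazol-5-yl in place of methoxy gives a 1.4-fold lower number from compound 2 to compound 4 (0.15 log units; within the scatter) in this assay. Among the compounds shown here, a five-membered aromatic ring with 2 hetero atoms and methoxy thus read alike here, so this change shows no counterpart to the large step at the saturated chain on the sulfonyl, a 42-fold lower number from compound 1 to compound 3 (1.62 log units; beyond the scatter). No available evidence explains this result.

On these data alone, whether an amine, a carboxylic acid or a longer chain at this carbon would also stay within the scatter of compound 2 remains open. So does the effect of replacing the chloro group.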